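This account rests on a few compounds, and the source may have more. Where it says the series, first, only, none or still open, it means among the compounds named here.

Measured so far:
- compound 1, `CC(C)(C)c1ccc(C(=O)N2CCC3(CC2)C(=O)N(CC(=O)NCCN)CN3c2ccccc2)cc1`, 7000 nM
- compound 2, `NC(=O)C1CCCN(C(=O)CN2CN(c3ccccc3)C3(CCN(C(=O)c4ccc(C5CCCCC5)cc4)CC3)C2=O)C1`, 3100 nM

Both values come from an assay on HEK293 cells for displacement of a labelled ligand from NPC1-like intracellular cholesterol transporter 1 (Homo sapiens); a lower number here means a stronger inhibitor, a higher number a weaker inhibitor. Compound 2 has the lowest of the two numbers; compound 1 is the nearest, with a number that lies beyond the scatter above it. No pair of these compounds differs in a single place, so no measured step is available.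

Compound 3, `NCCNC(=O)CN1CN(c2ccccc2)C2(CCN(C(=O)c3ccc(C4CCCCC4)cc3)CC2)C1=O`, is the next to be measured in this assay. It differs from compound 2 in one place: (2-aminoethyl)amino in place of 3-carbamoylpiperidin-1-yl on a carbonyl carbon. Within the data shown here, the expectation is a modest move toward a higher number, possibly no move beyond the scatter, since the only comparison among the measured compounds, compound 1 against compound 2, points to weaker binding with the (2-aminoethyl)amino tail but is entangled with a second change. The estimated step of a 1.5-fold higher number from compound 2 to compound 3 (0.16 log units; within the scatter) leads to an expected value for compound 3 of 4500 nM, with a range from 1500 nM to 14000 nM.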

Compound 3, half-maximal inhibitory concentration: 3800 nM
Beside the measured number, compound 3's estimate is 1.2-fold (0.07 log units) above it, and the stated range covers the measured number.
By their numbers in this assay, from the lowest: compounds 2, 3 and 1 (each within the scatter of the next, the first and the last beyond it).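

In this assay, (2-aminoethyl)amino in place of 3-carbamoylpiperidin-1-yl on a carbonyl carbon gives a 1.2-fold higher number from compound 2 to compound 3 (0.09 log units; within the scatter), so this position accepts an open chain instead of a six-membered ring with no shift that can be told from the scatter. With that chain held constant, cyclohexyl in place of tert-butyl on an aromatic carbon gives a 1.8-fold lower number from compound 1 to compound 3 (0.27 log units; within the scatter), so this single change also stays within the scatter. Nothing measured here offers an explanation for either result.

On these data alone, it remains open whether a longer chain, or a carboxylic acid in place of the amine of the (2-aminoethyl)amino group, would give a clearly different number. Phenyl in place of cyclohexyl on the aromatic carbon is equally open.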